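This account rests on a few compounds, and the source may have more. Where it says the series, first, only, none or still open, it means among the compounds named here.

Compound 1, `COc1ccc(CNC(=O)c2nc(-c3ccc(F)cc3)n(CC[C@@H](O)C[C@@H](O)CC(=O)O)c2C2CC2)cc1`, was tested in a functional assay on L6 cells (Rattus norvegicus) for inhibition, read by scintillation counting, with a stated time of 3 h (a lower number here means a stronger inhibitor, a higher number a weaker inhibitor), where compound 1 gives 6400 nM. Going by the values given here, of the two compounds measured so far, compound 1 has the highest number and is therefore the weaker inhibitor of the pair. The other measured compound, compound 2, `Cc1ccc(CNC(=O)c2nn(-c3ccc(F)cc3)c(CC[C@@H](O)C[C@@H](O)CC(=O)O)c2C(C)C)cc1`, gives 730 nM in this assay, a clearly lower number whose gap to compound 1 lies beyond the usual scatter. Compound 3, `O=C(O)C[C@H](O)C[C@H](O)CCn1c(-c2ccc(F)cc2)nc(C(=O)NCc2ccc(F)c(F)c2)c1C1CC1`, has not yet been measured. It differs from compound 1 in one place: 3,4-difluorophenyl in place of 4-methoxyphenyl on a saturated chain carbon bound to an amide-type nitrogen. Among the compounds with values here, no measured pair shows this particular change, so the data give no direct guide to the size of its effect. A modest step is therefore expected, a 1.8-fold lower number from compound 1 to compound 3 (0.26 log units; within the scatter), towards a somewhat lower number, although a result within the scatter would not be surprising. Compound 3 is estimated to give 3500 nM in this assay, with a likely range from 1000 nM to 12000 nM.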

Compound 3, half-maximal inhibitory concentration: 2780 nM
For compound 3 the middle estimate is 1.3-fold (0.10 log units) above the measured one, within the range that was stated.
By their numbers in this assay, from the lowest: compound 2; then compound 3; then compound 1.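

In this assay, putting 3,4-difluorophenyl in place of 4-methoxyphenyl gives a 2.3-fold lower number from compound 1 to compound 3 (0.36 log units; beyond the scatter). This shows that the number responds to the aromatic group at this place, on a saturated chain carbon bound to an amide-type nitrogen, although the step is modest. The change also removes the hydrogen-bond acceptor of the leaving group while the six-membered aromatic ring of carbon stays, but nothing shown gives a reason for the lower number.

The compounds shown do not separate the loss of the methoxy group from the arrival of the two fluorines. Still open, from the compounds shown here alone, is how this position would respond to a plain phenyl, a single fluorine, or a longer chain such as phenethyl in place of the benzyl group, each on the core of compound 1.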